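The compounds below may be only part of what the source reports. "The series", "measured", "known", "first", "only" and "open" are said of these compounds alone.

In an ADME assay on a cell-free system (plasma, Homo sapiens) for protein binding, compound 2 `CCOc1nc2nc(C)cc(Nc3ccc(C(F)(F)F)cc3)n2n1` gives 92.4%. That sits within the scatter of compound 3 `CCc1nc2nc(C)cc(Nc3ccc(C(F)(F)F)cc3)n2n1`, which gives 87.5%, while compound 1 `Cc1cc(Nc2ccc(C(F)(F)F)cc2)n2nc(CCO)nc2n1` gives only 67%.

Compound 4 `CCOc1nc2nc(C)cc(Nc3ccc(S(F)(F)(F)(F)F)cc3)n2n1` keeps the shared core and the ethoxy group of compound 2, and changes one group: a group of 6 heavy atoms (5 fluorine, 1 sulfur; no ring) in place of a group of 4 heavy atoms (1 carbon, 3 fluorine; no ring), on an aromatic carbon. The trifluoromethyl group leaves an aromatic carbon of a six-membered aromatic ring of carbon only, and the larger group takes its place.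

Among the measured compounds shown here, no measured step touches that site, so the evidence is indirect. The two steps that remove the hydroxy-bearing chain are modest but real: a 4.3-fold lower unbound fraction from compound 1 to compound 2 (0.64 log units; beyond the scatter) and a 2.6-fold lower unbound fraction from compound 1 to compound 3 (0.42 log units; beyond the scatter). For the measured compounds named here, the one step between two compounds without a hydroxy group is smaller: a 1.6-fold higher unbound fraction from compound 2 to compound 3 (0.22 log units; within the scatter). Compound 2 also already binds heavily, and neither of those facts points to a large move from a swap of this kind.

The estimated step is a 1.5-fold lower unbound fraction from compound 2 to compound 4 (0.18 log units; within the scatter), a small one towards less free compound that is not expected to clear the scatter. Compound 4 is expected at 95%, within a range of 89% to 98%.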

Compound 4, plasma protein binding: 97.7%
Beside the measured number, compound 4's estimate is 2.2-fold (0.34 log units) (unbound fraction) above it; the range from low to high includes it.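

In this assay, among the compounds shown here, the aromatic carbon that carries the trifluoromethyl group had not been varied in the earlier compounds, and this swap gives a 3.3-fold lower unbound fraction from compound 2 to compound 4 (0.52 log units; beyond the scatter). The site therefore responds to change, even in a compound that is already heavily bound and even though neither group has any hydrogen-bond donors or acceptors or a net charge. No measurement shown here explains why the larger group lowers the free fraction.

From the compounds shown here alone, it remains open whether the same swap would have a similar effect with the 2-hydroxyethyl chain of compound 1 or the ethyl group of compound 3 in place of the ethoxy group. The compounds also leave open how this site would respond to a different kind of group, such as a nitrile, an amine or a carboxylic acid.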